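Adding a fluoro-methoxyphenyl ring: a cytotoxicity check

The source may report more compounds than this note shows. Statements on the series, on what has been measured and on what is new or still open speak of the compounds shown alone.

Compound 1, `CC(C)N(Cc1cccc(OCCCCCC(=O)O)c1)C(=O)c1ccccc1`, gives > 26000 nM in an ADME assay on HepG2 cells (Homo sapiens) for cytotoxicity, read by CellTiter-Glo and resazurin assay, with a stated time of 72 h; a higher number here means that more compound is needed for the effect, a lower number that less compound is needed; this value is a limit of the assay, not a number.
Compound 2, `COc1cccc(-c2ccc(C(=O)N(Cc3cccc(OCCCCCC(=O)O)c3)C(C)C)cc2)c1`, gives > 26000 nM in this assay; this too is a limit of the assay.

Within the data shown here, compound 1 therefore stands at the edge of what the assay can report, and the same holds for the only other value shown, since (the limit of > 26000 nM in this assay, at which 2 of the 2 values shown sit). The step that the two limits leave unreadable from compound 1 to compound 2 cannot be sized, because both of its ends are limits. Compound 3, `COc1ccc(F)c(-c2ccc(C(=O)N(Cc3cccc(OCCCCCC(=O)O)c3)C(C)C)cc2)c1`, differs from compound 1 by 2-fluoro-5-methoxyphenyl in place of hydrogen on an aromatic carbon. Among the measured compounds shown here, the one measured step that starts from compound 1 offers no readable size, so no change beyond the scatter can be argued for from the data. For compound 3 the expectation is that the assay again reports a limit, with an estimated value of 40000 nM and a range from 20000 nM to 100000 nM. The step that the limit leaves unreadable from compound 1 to compound 3 is thus expected to show no cytotoxicity the assay can measure.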

Compound 3, half-maximal effective concentration: > 26000 nM
Compound 3: a limit, no number (the forecaster's own chance of this, stated with the estimate: 85%); the middle value is on the limit's open side.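

Compound 3, like compound 1 and compound 2, gives a limit and not a number, and the steps from compound 1 and from compound 2 to compound 3 cannot be read. In this assay the compounds shown leave open whether the added rings or the fluoro group change cytotoxicity at all, and at what concentration any of the three would show it.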